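Removing a Ring Methyl from a Fast-Cleared Compound

The compounds below may be only part of what the source reports. "The series", "measured", "known", "first", "only" and "open" are said of these compounds alone.

Compound 1 `CN1CCN(CCOc2nn(-c3ccccc3F)c3ccc(F)cc23)C1=O` was tested in an ADME assay on liver for metabolic stability, with Liver microsome (Rattus norvegicus) as the target, using microsomes and NADPH, with a stated time of 30 min, tested at 0.5 uM (on this read-out lower numbers stand for slow clearance and higher numbers for fast clearance), and gives 7200 mL/min/kg. Among the three compounds measured here, compound 1 stands highest. Compound 3 `CC(Oc1nn(-c2ccccc2F)c2ccc(F)cc12)C(=O)N1CCOCC1` gives 717 mL/min/kg, a gap from compound 1 that lies beyond the usual scatter. Compound 2 `CC(C)(C)OC(=O)N1CCN(c2cccc3c2cnn3-c2ccccc2F)C1=O` gives 120 mL/min/kg, the furthest from compound 1 and also beyond the scatter.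

Compound 4 `O=C1NCCN1CCOc1nn(-c2ccccc2F)c2ccc(F)cc12` has not yet been measured. It differs from compound 1 in one place: hydrogen in place of methyl on an amide-type nitrogen in a ring. Among the compounds with values here, no pair of measured compounds shows this same change, so there is no measured step to lean on, and the expectation rests on compound 1 alone. Because compound 1 sits at 7200 mL/min/kg, the highest number seen, a move toward slower clearance is expected rather than a further rise. The estimated step is a 2.4-fold lower number from compound 1 to compound 4 (0.38 log units; beyond the scatter), a modest fall that may just pass the scatter. Compound 4 is therefore expected to give 3000 mL/min/kg, within a range from 1200 mL/min/kg to 7500 mL/min/kg.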

Compound 4, clearance: 1380 mL/min/kg
The estimate for compound 4 lay 2.2-fold (0.34 log units) above the measured number; the measured number falls inside the stated range.
By their numbers in this assay, from the lowest: compound 2; then compounds 3 and 4 (each within the scatter of the next); then compound 1.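

In this assay the swap of methyl for hydrogen on the amide-type nitrogen in the ring gives a 5.2-fold lower number from compound 1 to compound 4 (0.72 log units; beyond the scatter) and so shows that this one position, where a single carbon leaves, has a bearing on clearance. The earlier compounds shown here could not show this: no two of them differed in one place only, so none of their gaps could be tied to a single change. Nothing measured here says why the number falls with this change. The compounds shown leave open whether the same swap would give a similar step on a different core. They also leave open how clearance would respond to an ethyl or acetyl group on this nitrogen, or to a longer chain in place of the 2-(2-oxoimidazolidin-1-yl)ethyl group.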